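Silyl-Protected Chain on a Triol Core: Expected Potency

The compounds below may be only part of what the source reports. "The series", "measured", "known", "first", "only" and "open" are said of these compounds alone.

Compound 1 `COc1cc(CC(O)(COCc2ccccc2)COCc2ccccc2)nc(OC)n1`: in a functional assay on MCF7 cells (Homo sapiens) for antiproliferative activity, read by MTT assay, with a stated time of 72 h (a lower number here means a stronger inhibitor, a higher number a weaker inhibitor), compound 1 gives > 100000 nM, a limit of the assay rather than a number.
Compound 2 `C[Si](C)(C)CCOCn1c(CC(O)(COCc2ccccc2)COCc2ccccc2)cc(=O)[nH]c1=O`: in this assay compound 2 gives > 100000 nM, again a limit of the assay.
Compound 3 `COCn1c(CC(O)(CO)CO)cc(=O)[nH]c1=O`: in this assay compound 3 gives > 100000 nM, also a limit of the assay.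

Compound 3 therefore stands where every measured compound here stands: at the limit of > 100000 nM in this assay, at which 3 of the 3 values shown sit, with no numerical potency resolved for any of them. Nothing among these results separates one compound from another.

Compound 4 `C[Si](C)(C)CCOCn1c(CC(O)(CO)CO)cc(=O)[nH]c1=O` is the next compound to be measured in this assay. Compared with compound 3 it carries a group of 5 heavy atoms (4 carbon, 1 silicon; no ring) in place of a hydrogen atom, on a saturated chain carbon bound to an oxygen on a saturated carbon. The same kind of group appears in compound 2, which in this assay sits at its limit of > 100000 nM, a result that gives no hint of a gain in potency.

Given that compound 3 rests at a limit and that the related compound 2 does the same, the expected step from compound 3 to compound 4 is a step that the limit leaves unreadable from compound 3 to compound 4, that is, no change beyond the scatter. Compound 4 is therefore estimated to give about 150000 nM in this assay, with a plausible range from 50000 nM to 500000 nM, and most likely only a limit will be reported.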

Compound 4, half-maximal inhibitory concentration: > 100000 nM
Compound 4 gave a limit, no number; the forecaster's own chance of this, stated with the estimate: 85%; the middle value does not contradict the limit.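

Within the data shown here, compound 4 gives a limit rather than a number, just as compound 3 does, so no step between compound 3 and compound 4 can be read: the limit of > 100000 nM in this assay, at which 4 of the 4 values shown sit. The compounds shown leave open whether any structure in this family has a measurable potency in this assay.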